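Para-substituent swap on the benzoyl of a trimethoxyphenyl series

The source may report more compounds than this note shows. Statements on the series, on what has been measured and on what is new or still open speak of the compounds shown alone.

Compounds so far:
compound 1 `COc1cc(-c2nnc3n2NC(c2ccco2)C(C(=O)c2ccco2)S3)cc(OC)c1OC`, 68700 nM
compound 2 `COc1ccc(C(=O)C2Sc3nnc(-c4cc(OC)c(OC)c(OC)c4)n3NC2c2ccco2)cc1`, limit > 100000 nM
compound 3 `COc1cc(-c2nnc3n2NC(c2ccco2)C(C(=O)c2ccc(Cl)cc2)S3)cc(OC)c1OC`, 51400 nM

In a functional assay on A549 cells (Homo sapiens) for cytotoxicity, read by MTT assay, with a stated time of 48 h (on this read-out lower numbers stand for stronger inhibition and higher numbers for weaker inhibition), compound 3 gives the lower of the two numbers, yet compound 1 sits within the scatter of it a 1.3-fold lower number from compound 1 to compound 3 (0.13 log units; within the scatter). For compound 2 only a limit of this assay is recorded, > 100000 nM (the limit of > 100000 nM in this assay, at which 1 of the 3 values shown sits).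

Compound 4 `COc1cc(-c2nnc3n2NC(c2ccco2)C(C(=O)c2ccc([N+](=O)[O-])cc2)S3)cc(OC)c1OC` differs from compound 3 in one place: nitro in place of chloro on an aromatic carbon. The step that bears most directly on it is the earlier swap on the same aromatic carbon, chloro in place of methoxy an at least 1.9-fold lower number from compound 2 to compound 3 (0.28 log units; that floor lies within the scatter), whose floor lies within the scatter. The swap of the whole aryl on the carbonyl carbon a 1.3-fold lower number from compound 1 to compound 3 (0.13 log units; within the scatter) also stayed within the scatter. Variation at this position has so far moved the number little, so for compound 4 no step beyond the scatter is expected in this assay; the estimate is a 1.2-fold higher number from compound 3 to compound 4 (0.07 log units; within the scatter). Compound 4 is estimated at 60000 nM, between 30000 nM and 120000 nM.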

Compound 4, half-maximal inhibitory concentration: > 100000 nM
Compound 4: only a limit was reported; the forecaster's own chance of this, stated with the estimate: 25%; middle value at least 1.6-fold (0.22 log units) away from the limit.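

In this assay, nitro in place of chloro gives an at least 1.9-fold higher number from compound 3 to compound 4 (0.28 log units; that floor lies within the scatter), and the comparison with the furan-2-yl compound gives an at least 1.4-fold higher number from compound 1 to compound 4 (0.16 log units; that floor lies within the scatter); both floors lie within the scatter, so neither step establishes a real loss. The new information is that nitro, like methoxy in compound 2, gives only a limit on this aromatic carbon, leaving chloro in compound 3 as the only substituent there with a readable number: the limit of > 100000 nM in this assay, at which 2 of the 4 values shown sit. The step between compound 2 and compound 4 cannot be read, as both carry limits.

On these data alone, how far compound 2 and compound 4 lie beyond the limit remains open, so any true difference from compound 3 stays unsized. Also open, as far as these compounds go, is whether an amine or a carboxylic acid on this aromatic carbon would give a readable number.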